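From hydroxy to benzyloxy: compound 3 to compound 4

This account rests on a few compounds, and the source may have more. Where it says the series, first, only, none or still open, it means among the compounds named here.

Measured so far in an ADME assay on CCRF-CEM cells (Homo sapiens) for cytotoxicity, read by MTT assay, with a stated time of 72 h (on this read-out higher numbers stand for lower toxicity in this test and lower numbers for higher toxicity in this test), as follows
- compound 1 (`CC(C)CC(=O)c1c(O)c(C(=O)CC(C)C)c(O)c(C(CCc2ccccc2)c2c(O)c(C(=O)CC(C)C)c(O)c(C(=O)CC(C)C)c2O)c1O`) result ("not determined" (no result reported))
- compound 2 (`CC(C)CC(=O)c1c(O)c(C(=O)CC(C)C)c(O)c(C(c2ccccc2)c2c(O)c(C(=O)CC(C)C)c(O)c(C(=O)CC(C)C)c2O)c1O`) result (3150 nM)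
- compound 3 (`CC(C)CC(=O)c1c(O)c(C(=O)CC(C)C)c(O)c(C(c2ccc(O)cc2)c2c(O)c(C(=O)CC(C)C)c(O)c(C(=O)CC(C)C)c2O)c1O`) result ("not determined" (no result reported))

Compound 3 has no place on the numbers, as no single value was reported for it ("not determined" (no result reported)). For the measured compounds named here, the same holds for compound 1, so compound 2 is the only member of the series with a measured value. Compound 4 (`CC(C)CC(=O)c1c(O)c(C(=O)CC(C)C)c(O)c(C(c2ccc(OCc3ccccc3)cc2)c2c(O)c(C(=O)CC(C)C)c(O)c(C(=O)CC(C)C)c2O)c1O`) has not yet been measured. It differs from compound 3 by hydroxy to benzyloxy (benzyl in place of hydrogen on an oxygen on an aromatic ring), with benzyl in place of hydrogen on an oxygen on an aromatic ring.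

Going by the values given here, no measured step shows what such a change does. Among the compounds with values here, the only guide in this assay is compound 2 (3150 nM), and compound 4 is expected to lie within the usual scatter of that value, with neither direction favoured. The uncertainty is wide, given this single reference point. For compound 4 the estimated value is 3000 nM with an expected range from 1000 nM to 9000 nM in this test.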

Compound 4, half-maximal cytotoxic concentration: 24000 nM
Beside the measured number, compound 4's estimate is 8.0-fold (0.90 log units) below it; measured number above the stated range.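

In this assay the series now has its first measured step, a 7.6-fold higher number from compound 2 to compound 4 (0.88 log units; beyond the scatter), which places benzyloxy in place of hydrogen on an aromatic carbon and goes with lower toxicity in this test, beyond the scatter. Compound 3 has no single number, so the change from hydroxy to benzyloxy cannot itself be read, and the step shows only that this position tolerates a large change in the read-out. No supporting data bear on what lies behind this shift.

Going by these compounds, it remains open whether a methoxy group, an amine or a carboxylic acid on the same aromatic ring would shift the number in the same way. On these data alone, it is also open whether the aromatic ring of the benzyl group matters, or whether a plain longer chain on that oxygen would do the same.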